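The source may hold more compounds than are shown below. What is called first, only, known or untested is meant among the compounds shown, and "the series" means these compounds.

Working notes on the series.

Of the compounds shown here, three have been measured in an ADME assay on MDCK cells (Canis lupus familiaris) for cytotoxicity; on this read-out lower numbers stand for higher toxicity in this test and higher numbers for lower toxicity in this test. Compound 1 `Cc1ncc(Sc2nccn2C)c(-c2ccccc2O)n1` gives 577000 ug/mL and stands highest of the three. Compound 2 `CC(C)(C)c1ncc(Sc2nc[nH]n2)c(-c2cc(Cl)ccc2O)n1` gives 9580 ug/mL in this assay, and compound 3 `COc1ccc(O)c(-c2nc(SC)ncc2Sc2nccn2C)c1` gives 7190 ug/mL; both numbers lie well beneath that of compound 1, with both gaps beyond the scatter. Compound 1 thus marks the least toxic point seen so far in this assay, while compounds 2 and 3 sit close to one another at the lower end.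

Compound 4 `Cn1ccnc1Sc1cnc(-c2ccc(N)cc2)nc1-c1ccccc1O` has not yet been measured in this assay. It departs from compound 1 by a single change: 4-aminophenyl in place of methyl on an aromatic carbon. Within the data shown here, no pair of measured compounds differs in only one place, so no measured step is available to anchor the size of this change, and the expectation rests on the spread of the three numbers alone.

The step of a 14-fold lower number from compound 1 to compound 4 (1.16 log units; beyond the scatter) is expected to run downward, toward higher toxicity in this assay, and to exceed the scatter. Compound 4 is estimated to give 40000 ug/mL in this assay, with a range of 4000 ug/mL to 400000 ug/mL.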

Compound 4, half-maximal cytotoxic concentration: 80100 ug/mL
Beside the measured number, compound 4's estimate is 2.0-fold (0.30 log units) below it; measured number inside the range.
By their numbers in this assay, from the lowest: compounds 3 and 2 (each within the scatter of the next); then compound 4; then compound 1.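

Among these compounds, this is the first single-place comparison: on the aromatic carbon between two ring nitrogen atoms, 4-aminophenyl in place of methyl gives a 7.2-fold lower number from compound 1 to compound 4 (0.86 log units; beyond the scatter) in this assay. The position therefore responds to this change, and the shift runs toward higher toxicity in this test by more than the usual scatter, although the step is modest given that one heavy atom is replaced by a group of seven heavy atoms carrying an aromatic ring and a hydrogen-bond donor. Nothing measured beyond the cytotoxicity read-out bears on the reason for this step, which therefore stands as an observation on this one pair.

A single step cannot separate the contribution of the added aromatic ring from that of the amine on it, so a plain phenyl, or a phenyl ring carrying a carboxylic acid in place of the amine, would be needed at this carbon to tell the two apart. Also open, from the compounds shown here alone, is how a small group such as an ethyl chain or a directly attached amine would fare at the same place, and whether the step keeps its direction and size on a different substitution of the shared core.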